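This account rests on a few compounds, and the source may have more. Where it says the series, first, only, none or still open, it means among the compounds named here.

Three compounds sharing one core were tested in a functional assay on HCT-116 cells (Homo sapiens) for inhibition, read by MTT assay, with a stated time of 24 h, tested at 5 uM; a lower number here means less inhibition of growth, a higher number more inhibition of growth at the concentration tested. Compound 1 `N#Cc1ccc(-c2cnc3[nH]cc(-c4nnc(-c5ccc(Cl)cc5)o4)c(=O)c3c2)cc1` gives 17.9% in this assay. Compound 2 `O=c1c(-c2nnc(-c3ccc(F)cc3)o2)c[nH]c2ncc(-c3ccncc3)cc12` gives 10.9%. Compound 3 `Cc1ccc(-c2nnc(-c3c[nH]c4ncc(-c5ccc(S(C)(=O)=O)cc5)cc4c3=O)o2)cc1` gives 20.4%, the highest of the three numbers, though its gaps to compound 1 and to compound 2 both lie within the usual scatter, so no ranking among the three can be drawn. Compound 4 `Cc1cccc(-c2nnc(-c3c[nH]c4ncc(-c5ccc(S(C)(=O)=O)cc5)cc4c3=O)o2)c1` has not yet been measured. It differs from compound 3 in one place: 3-methylphenyl in place of 4-methylphenyl on an aromatic carbon. Among the compounds with values here, no measured pair shows this kind of change, and the two groups are counted alike, so no step beyond the scatter is expected in either direction. Compound 4 is therefore expected to give about 19% in this assay, within a range from 8% to 32%. The expected step of a number 1.4 percentage points lower from compound 3 to compound 4 (within the scatter) is estimated to stay inside the scatter.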

Compound 4, percent growth inhibition at one concentration: 20.4%
The estimate for compound 4 lay 1.4 percentage points below the measured number; low and high end bracket the measured number.
By their numbers in this assay, from the lowest: compounds 2, 1, 3 and 4 (each within the scatter of the next).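

The step of no change at the digits printed from compound 3 to compound 4 (within the scatter) in this assay comes from 3-methylphenyl in place of 4-methylphenyl on an aromatic carbon of a five-membered aromatic ring. Within the data shown here, it gives the first pair here that differs in one place, and it shows that this change at this position leaves the number within the scatter. Nothing at hand explains this result. Still open, going by these compounds, is whether a group of another kind at this position, such as an amine or a carboxylic acid, would take the number beyond the scatter.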